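Nitro for Trifluoromethyl on a Macrocyclic Quinazoline Series

The source may hold more compounds than are shown below. What is called first, only, known or untested is meant among the compounds shown, and "the series" means these compounds.

Measured compounds:
compound 1, `FC(F)(F)c1ccc(COc2cccc(Nc3ncnc4cc5c(cc34)OCCOCCOCCOCCO5)c2)cc1`, 26900 nM
compound 2, `FC(F)(F)c1ccc(COc2ccc(Nc3ncnc4cc5c(cc34)OCCOCCOCCOCCO5)cc2)cc1`, 8800 nM
compound 3, `O=[N+]([O-])c1ccc(COc2cccc(Nc3ncnc4cc5c(cc34)OCCOCCOCCOCCO5)c2)cc1`, 13800 nM

In a functional assay on DU-145 cells (Homo sapiens) for antiproliferative activity, read by MTT assay, with a stated time of 72 h (a higher number here means a weaker inhibitor, a lower number a stronger inhibitor), compound 1 gives 26900 nM. Compound 3 shares its core but carries a different group on the benzyl ring; the difference is nitro in place of trifluoromethyl on an aromatic carbon. That change made a step of a 1.9-fold lower number from compound 1 to compound 3 (0.29 log units; within the scatter). Compound 2 has the same atoms as compound 1 joined differently, and the difference between the two cores is not broken down here. In this assay compound 2 gives 8800 nM, a value beyond the scatter from compound 1 and within the scatter of compound 3.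

Compound 4, `O=[N+]([O-])c1ccc(COc2ccc(Nc3ncnc4cc5c(cc34)OCCOCCOCCOCCO5)cc2)cc1`, has not yet been measured. It differs from compound 2 by nitro in place of trifluoromethyl on an aromatic carbon. This is the same change as from compound 1 to compound 3, made on the core of compound 2, and the place lines of the two changes read alike. Within the data shown here, since the only measured example of this change, a 1.9-fold lower number from compound 1 to compound 3 (0.29 log units; within the scatter), stayed within the scatter, the step from compound 2 to compound 4 is expected to be small as well, about a 1.8-fold lower number from compound 2 to compound 4 (0.25 log units; within the scatter). Among the measured compounds shown here, compound 4 is therefore estimated at 5000 nM in this assay, with a plausible range from 2000 nM to 12000 nM, because the single precedent a 1.9-fold lower number from compound 1 to compound 3 (0.29 log units; within the scatter) points only weakly toward a lower number.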

Compound 4, half-maximal inhibitory concentration: > 100000 nM
Compound 4 gave a limit, no number; the forecaster's own chance of this, stated with the estimate: 0%; middle value at least 20-fold (1.30 log units) away from the limit.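

In this assay compound 4 gives > 100000 nM, which is a limit of the assay and not a number. Read against the earlier value, nitro in place of trifluoromethyl gives an at least 11-fold higher number from compound 2 to compound 4 (1.05 log units; beyond the scatter), so in this series the result of the change on one core did not predict its result on the other: the same change on two cores in this assay, a 1.9-fold lower number (0.29 log units; within the scatter) from compound 1 to compound 3 and an at least 11-fold higher number (1.05 log units; beyond the scatter) from compound 2 to compound 4, at least 22-fold (1.34 log units) apart, beyond the scatter of two such steps. From the compounds shown here alone, this rests on just two pairs of compounds, so it shows that the outcome of the change can differ with the core, but not what about the two cores sets that difference, and the upper end of the new step remains unknown: the limit of > 100000 nM in this assay, at which 1 of the 4 values shown sits.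

The compounds shown leave open whether another group on the benzyl ring, such as a nitrile or an amine, would give a small step on one core and a large one on the other, as nitro does here. They also leave open whether the same split between the two cores would appear in any other assay, since all four compounds are compared here in this assay alone.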